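This account rests on a few compounds, and the source may have more. Where it says the series, first, only, none or still open, it means among the compounds named here.

Measured so far in the series:

compound 1, `Nc1scc(CN2CCN(c3ccccc3)CC2)c1C(=O)c1ccc(Cl)cc1` — 1.9 nM
compound 2, `Nc1scc(CN2CCN(c3ccc(Cl)cc3)CC2)c1C(=O)c1ccc(Cl)cc1` — 1.8 nM

In an assay on CHO cells for displacement of a labelled ligand from adenosine receptor A1 (Homo sapiens) (on this read-out lower numbers stand for tighter binding and higher numbers for weaker binding), compound 2 gives 1.8 nM. Among the measured compounds shown here, its only neighbour on the numbers is compound 1, and the step of a 1.1-fold lower number from compound 1 to compound 2 (0.02 log units; within the scatter) lies within the scatter, so the two compounds cannot be separated on this read-out.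

Compound 3, `Cc1ccc(N2CCN(Cc3csc(N)c3C(=O)c3ccc(Cl)cc3)CC2)cc1`, is the next candidate. It differs from compound 2 in one place: methyl in place of chloro on an aromatic carbon. For the measured compounds named here, the one measured step that touches this position is a 1.1-fold lower number from compound 1 to compound 2 (0.02 log units; within the scatter), chloro for hydrogen on the same aromatic carbon, and it left the number essentially unchanged. Exchanging chloro for methyl at that same place is therefore expected to give, in this assay, a step of about a 1.1-fold higher number from compound 2 to compound 3 (0.05 log units; within the scatter), that is, nothing beyond the scatter in either direction. The estimate for compound 3 in this assay is 2 nM, with a range of 0.9 nM to 4.5 nM.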

Compound 3, dissociation constant: 1.7 nM
Compound 3: the middle estimate sits 1.2-fold (0.07 log units) above what was measured, within the range that was stated.
By their numbers in this assay, from the lowest: compounds 3, 2 and 1 (each within the scatter of the next).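

In this assay the exchange of 4-chlorophenyl for 4-methylphenyl gives a 1.1-fold lower number from compound 2 to compound 3 (0.02 log units; within the scatter) and methyl in place of hydrogen on the same aromatic carbon gives a 1.1-fold lower number from compound 1 to compound 3 (0.05 log units; within the scatter). The earlier pair covered only hydrogen and chloro at this carbon, para to a large group; with methyl added, all three substituents remain within the scatter of one another, so this read-out does not separate them. No measurement is available to explain this absence of separation.

The compounds shown leave open whether an amine, a carboxylic acid or a longer chain on this carbon would also stay within the scatter of compound 1. They also leave open whether chloro or methyl on another carbon of the same ring would do so.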